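This account rests on a few compounds, and the source may have more. Where it says the series, first, only, none or still open, it means among the compounds named here.

The measured compounds are two. Compound 1 `N#CC1=C(N)Oc2c(c3nc4ccccc4nc3c3ccccc23)C12C(=O)N(Cc1cnnn1-c1ccc(F)cc1)c1ccccc12` in an ADME assay on HUVEC cells (Homo sapiens) for antiproliferative activity, read by MTT assay, with a stated time of 48 h (on this read-out higher numbers stand for weaker inhibition and lower numbers for stronger inhibition), gives > 50000 nM, which is a limit of the assay and not a number. Compound 2 `Cc1ccc(-n2nncc2CN2C(=O)C3(C(C#N)=C(N)Oc4c3c3nc5ccccc5nc3c3ccccc43)c3ccccc32)c(C)c1` in this assay gives > 50000 nM, likewise a limit.

Compound 2 therefore stands at the edge of what this assay reports, with a bound and no number to its name. The change to compound 3 `N#CC1=C(N)Oc2c(c3nc4ccccc4nc3c3ccccc23)C12C(=O)N(Cc1cnnn1-c1cc(Cl)ccc1Cl)c1ccccc12` is 2,5-dichlorophenyl in place of 2,4-dimethylphenyl on an aromatic nitrogen. Going by the values given here, the one measured step that touches this position, a step that the two limits leave unreadable from compound 1 to compound 2, cannot be read because of the limit of > 50000 nM in this assay, at which 2 of the 2 values shown sit. No numbered value exists here for any variation at this aromatic nitrogen, so the expectation for compound 3 rests on the two limits alone. Compound 3 is expected, like the two measured compounds, most likely to reach only the limit again, the estimated step being a step that the limit leaves unreadable from compound 2 to compound 3. The estimate for compound 3 is 60000 nM, with a range from 20000 nM to 200000 nM.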

Compound 3, half-maximal inhibitory concentration: > 50000 nM
Compound 3: no number, only a limit; the forecaster's own chance of this, stated with the estimate: 85%; the middle value lies beyond the limit too.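

Compound 3 also gives only a limit in this assay, so the steps linking compound 1, compound 2 and compound 3 cannot be read, because all three sit at the same limit: the limit of > 50000 nM in this assay, at which 3 of the 3 values shown sit. The compounds shown leave open whether any group on this aromatic nitrogen would give a measurable value.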